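A Change at the Double-Bonded Nitrogen of Compound 1

The compounds below may be only part of what the source reports. "The series", "measured", "known", "first", "only" and "open" are said of these compounds alone.

Going by the values given here, compound 1 `N#CCC(=O)N/N=C1\C(=O)Nc2ccc(S(=O)(=O)N3CCOCC3)cc21` was tested in a functional assay on HCT-116 cells (Homo sapiens) for cytotoxicity, read by sulforhodamine B assay, with a stated time of 24 h (on this read-out lower numbers stand for stronger inhibition and higher numbers for weaker inhibition), where compound 1 gives 10300 nM, the higher of the two numbers measured so far. Compound 2 `N=c1oc2ccccc2cc1C(=O)N/N=C1\C(=O)Nc2ccc(S(=O)(=O)N3CCOCC3)cc21` gives 6750 nM in this assay; the step of a 1.5-fold lower number from compound 1 to compound 2 (0.18 log units; within the scatter) exchanged a group on a carbonyl carbon. Compound 3 `O=C1Nc2ccc(S(=O)(=O)N3CCOCC3)cc2/C1=N/c1ccc(C(=O)O)cc1` differs from compound 1 at another place: 4-carboxyphenyl in place of ((cyanomethyl)carbonyl)amino on a double-bonded nitrogen. Among the compounds with values here, only the step from compound 1 to compound 2 offers a comparison, it touched a different part of the shared core and stayed within the scatter, so no step beyond the scatter is expected here, and the expected step is a 1.0-fold lower number from compound 1 to compound 3 (0.01 log units; within the scatter). Compound 3 is therefore estimated at 10000 nM, with a range from 3000 nM to 33000 nM.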

Compound 3, half-maximal inhibitory concentration: 23600 nM
Compound 3: middle estimate off by 2.4-fold (0.37 log units), on the low side; measured number inside the range.
By their numbers in this assay, from the lowest: compounds 2 and 1 (each within the scatter of the next); then compound 3.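

In this assay, a change on the double-bonded nitrogen moves the number beyond the scatter, with a 2.3-fold higher number from compound 1 to compound 3 (0.36 log units; beyond the scatter) for 4-carboxyphenyl in place of ((cyanomethyl)carbonyl)amino. The step is modest, but it points toward weaker inhibition, whereas the earlier change on the carbonyl carbon stayed within the scatter. Nothing available explains this step. Going by these compounds, it remains open whether the ring or the carboxylic acid accounts for the difference, and a plain phenyl group on this nitrogen would help separate the two. How an amine or a longer chain would fare here is also unknown.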